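Furan for thiophene on the shared core at one concentration

The compounds below may be only part of what the source reports. "The series", "measured", "known", "first", "only" and "open" are said of these compounds alone.

Measured compounds:
compound 1 `OC1=CC(c2ccccc2)=NCC2(CN3CCC2CC3)N1` — 15%
compound 2 `O=C1CC(c2ccc(Br)s2)=NCC2(CN3CCC2CC3)N1` — 62%
compound 3 `O=C1CC(c2cccs2)=NCC2(CN3CCC2CC3)N1` — 20%

In an in vitro assay on SH-EP1 cells for displacement of a labelled ligand from Neuronal acetylcholine receptor; alpha4/beta2 (Homo sapiens), tested at 5 uM (on this read-out higher numbers stand for more inhibition at the one concentration tested (going by the name of the read-out) and lower numbers for less inhibition), compound 3 gives 20%, the second highest of the three numbers. Its nearest neighbour is compound 1, whose 15% lies within the usual scatter of it; the furthest is compound 2, which stands above it beyond the scatter. Among the measured compounds shown here, the one step measured in one place, a number 42 percentage points lower from compound 2 to compound 3 (beyond the scatter), concerns hydrogen in place of bromo on an aromatic carbon and does not touch the change now at hand.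

Compound 4 `O=C1CC(c2ccco2)=NCC2(CN3CCC2CC3)N1` differs from compound 3 by furan-2-yl in place of thiophen-2-yl on a carbon with a double bond to nitrogen. For the measured compounds named here, no measured pair swaps one five-membered aromatic ring with 1 hetero atom for another, so there is no step to lean on. Given that compound 1 with a phenyl ring and compound 3 with a thiophen-2-yl ring sit within the scatter of each other, compound 4 is expected to stay in that neighbourhood, with a number 4 percentage points lower from compound 3 to compound 4 (within the scatter), a change not beyond the scatter. Compound 4 is estimated at 16%, between 5% and 30%.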

Compound 4, a percentage reported as inhibition, at one concentration (the size of the read-out at that concentration, not a potency): 14%
For compound 4 the middle estimate is 2 percentage points above the measured one; the range from low to high includes it.
By their numbers in this assay, from the lowest: compounds 4, 1 and 3 (each within the scatter of the next); then compound 2.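

Among the compounds shown here, on the carbon with a double bond to nitrogen, the first exchange of one five-membered aromatic ring with 1 hetero atom for another gives, in this assay, a number 6 percentage points lower from compound 3 to compound 4 (within the scatter), so the data separate furan-2-yl from thiophen-2-yl by no readable margin. The second step, a number 48 percentage points lower from compound 2 to compound 4 (beyond the scatter), exchanges the ring and drops the bromo together, and it shows that neither ring without bromo comes near the number of compound 2. No measurement shown gives a cause for these numbers.

As far as these compounds go, whether bromo on furan-2-yl would raise the number as it does on thiophen-2-yl remains open. Also open, from the compounds shown here alone, is what a chloro group, a methyl group or an amine would do in place of the bromo on the thiophen-2-yl ring.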